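The source may hold more compounds than are shown below. What is called first, only, known or untested is meant among the compounds shown, and "the series" means these compounds.

Compound 1 `CC[C@H](NC(C)=O)c1cc(Cl)ccc1C1CCN(C(=O)[C@H]2CN(C(C)(C)C)C[C@@H]2c2ccc(Cl)cc2Cl)CC1` gives 3.3 nM in an assay on CHO cells for displacement of a labelled ligand from Melanocortin receptor 4 (Homo sapiens); on this read-out lower numbers stand for stronger inhibition and higher numbers for weaker inhibition. Compound 2 `CC[C@H](NC(C)=O)c1cc(Cl)ccc1C1CCN(C(=O)[C@H]2CN(C(C)(C)C)C[C@@H]2c2ccc(F)cc2Cl)CC1` gives 82.2 nM in this assay, the step being a 25-fold higher number from compound 1 to compound 2 (1.40 log units; beyond the scatter). Compound 3 `CC[C@H](NC(C)=O)c1cc(Cl)ccc1C1CCN(C(=O)[C@@H]2CN(C(C)(C)C)C[C@H]2c2ccc(F)cc2Cl)CC1` gives 216 nM, the highest of the three numbers, the step to it being a 2.6-fold higher number from compound 2 to compound 3 (0.42 log units; beyond the scatter) due to the fact that compounds 2 and 3 differ only in the configuration as drawn. Compound 4 `CC[C@H](NC(C)=O)c1cc(Cl)ccc1C1CCN(C(=O)[C@@H]2CN(C(C)(C)C)C[C@H]2c2ccc(Cl)cc2F)CC1` differs from compound 3 by 4-chloro-2-fluorophenyl in place of 2-chloro-4-fluorophenyl on a saturated ring carbon, an exchange within the aryl ring on the five-membered ring. The large step between compound 1 and compound 2, where chloro gave way to fluoro, bears on this change; the modest stereochemical step bears on it less. A lower number is therefore expected for compound 4, a step of a 3.6-fold lower number from compound 3 to compound 4 (0.56 log units; beyond the scatter). The estimate for compound 4 in this assay is 60 nM, within 10 nM to 400 nM.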

Compound 4, half-maximal inhibitory concentration: 6.2 nM
The estimate for compound 4 lay 9.7-fold (0.99 log units) above the measured number; the measured number lies below the stated range.
By their numbers in this assay, from the lowest: compounds 1 and 4 (each within the scatter of the next); then compound 2; then compound 3.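

With the configuration held and the same atoms joined differently, the exchange of 2-chloro-4-fluorophenyl for 4-chloro-2-fluorophenyl gives in this assay a 35-fold lower number from compound 3 to compound 4 (1.54 log units; beyond the scatter), so the number responds to where each halogen sits on this aryl ring and not only to which halogens it carries. The step of a 25-fold higher number from compound 1 to compound 2 (1.40 log units; beyond the scatter) and this one both leave the lower number with a 4-chloro aryl ring, and no compound shown goes against that. Nothing shown accounts for the size of this step. Still open, from the compounds shown here alone, is whether a methoxy or trifluoromethyl group in place of that chlorine would hold the number, and whether the same exchange behaves alike in the configuration of compound 2.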